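From phenyl to 4-chlorophenyl on an inactive compound

A few compounds are considered here, and "the series" means these few. Any claim that something is new, unique, unknown or untested is made for them only; others in the source may bear on it.

In a functional assay on HO8910 cells (Homo sapiens) for inhibition, read by MTT assay, with a stated time of 24 h, tested at 100 ug/mL (on this read-out higher numbers stand for more inhibition of growth at the one concentration tested and lower numbers for less inhibition of growth), compound 1 `O=C(CCCCC(S)CCS)NO` gives a measurable reading (49.3%). Compound 2 `O=C(CCCCC(CCSC(=O)c1ccccc1)SC(=O)c1ccccc1)Nc1ccccc1` has no single number on this read-out and is reported only as ("not active" (no number reported)). Compound 3 `O=C(CCCCC(CCSC(=O)c1ccccc1)SC(=O)c1ccccc1)Nc1ccc(Cl)cc1` differs from compound 2 by chloro in place of hydrogen on an aromatic carbon, para to a large group (chloro in place of hydrogen on an aromatic carbon). Within the data shown here, no measured step gauges this change. From the reading of compound 2 ("not active" (no number reported)), only a small rise in this assay is expected, or none beyond the scatter. For compound 3 the expected value is 10% (estimated range 0% to 30%).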

Compound 3, percent growth inhibition at one concentration: "not active" (no number reported)
No number was reported for compound 3, and the estimate cannot be compared.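

Compound 2 and compound 3 both carry no number in this assay, and no step can be read between them. Nothing measured here bears on this result. The compounds shown leave open what phenyl to 4-chlorophenyl does to growth inhibition on a compound with a measurable reading.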